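The source may report more compounds than this note shows. Statements on the series, on what has been measured and on what is new or still open speak of the compounds shown alone.

Among the compounds with values here, in a functional assay for inhibition, with Homo sapiens as the target (a higher number here means a weaker inhibitor, a lower number a stronger inhibitor), compound 1 (`Cc1cc2c(cc1C(=O)N=C(N)N)S(=O)(=O)CC2C(C)C`) gives 77 nM and holds the lower of the two numbers so far, which makes it the stronger inhibitor, while compound 2 (`Cc1cc2c(cc1C(=O)N=C(N)N)S(=O)(=O)C(C)(C)C2O`) gives 258 nM as the higher number. Compound 3 (`COC1CS(=O)(=O)c2cc(C(=O)N=C(N)N)c(C)cc21`) has not yet been measured. It has methoxy in place of isopropyl on a saturated ring carbon of the core of compound 1. Within the data shown here, no measured pair shows this change, so the expectation is loose. A weaker inhibitor is expected, with an estimated step of a 3.9-fold higher number from compound 1 to compound 3 (0.59 log units; beyond the scatter) that would lie beyond the scatter. In this assay the estimate for compound 3 is 300 nM (expected range 90 nM to 1000 nM).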

Compound 3, half-maximal inhibitory concentration: 208 nM
The estimate for compound 3 lay 1.4-fold (0.16 log units) above the measured number; the measured number falls inside the stated range.
By their numbers in this assay, from the lowest: compound 1; then compounds 3 and 2 (each within the scatter of the next).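

In this assay putting methoxy in place of isopropyl on a saturated ring carbon gives a 2.7-fold higher number from compound 1 to compound 3 (0.43 log units; beyond the scatter) as a modest loss of inhibition. Within the data shown here, this is the first direct sign that this carbon, two ring bonds from the ring sulfur, is sensitive to the group it carries. No available evidence explains the change. The compounds shown leave open how an amine or a longer chain such as butyl on this carbon would compare with isopropyl and methoxy.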